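Series notes: acetyl to 4-methoxybenzyl on the shared core

This account rests on a few compounds, and the source may have more. Where it says the series, first, only, none or still open, it means among the compounds named here.

Three compounds of the series have been run in a functional assay on MDA-MB-231 cells (Homo sapiens) for inhibition, read by MTT assay, with a stated time of 48 h (on this read-out lower numbers stand for stronger inhibition and higher numbers for weaker inhibition), so far. Compound 1 `O=C1Nc2ccc(F)cc2/C1=C\c1cccc(OCc2cn(Cc3ccccc3)nn2)c1` carries fluoro on the shared core; in this assay compound 1 gives > 50000 nM, which is a limit of the assay and not a number. Compound 2 `CC(=O)c1ccc2c(c1)/C(=C/c1cccc(OCc3cn(Cc4ccccc4)nn3)c1)C(=O)N2` carries acetyl on the shared core with the double bond drawn Z; in this assay compound 2 gives > 50000 nM, again a limit rather than a number. Compound 3 `CC(=O)c1ccc2c(c1)/C(=C\c1cccc(OCc3cn(Cc4ccccc4)nn3)c1)C(=O)N2` is the same as compound 2 with the double bond drawn E; in this assay compound 3 gives > 50000 nM, also a limit. Compound 3 thus stands at the limit together with the other two, and the step that the two limits leave unreadable from compound 1 to compound 3 as well as the step that the two limits leave unreadable from compound 2 to compound 3 cannot be sized, given the limit of > 50000 nM in this assay, at which 3 of the 3 values shown sit, and (the fact that compounds 2 and 3 differ only in the configuration as drawn).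

Compound 4 `COc1ccc(Cc2ccc3c(c2)/C(=C\c2cccc(OCc4cn(Cc5ccccc5)nn4)c2)C(=O)N3)cc1` differs from compound 3 by 4-methoxybenzyl in place of acetyl on an aromatic carbon. Neither measured step bears readably on this change, since each starts and ends at the limit. Among the measured compounds shown here, no direction and no size can be read for this assay from the data in hand; the only anchor is that every value so far sits at the limit. Compound 4 is therefore expected to give 60000 nM, within 12000 nM to 300000 nM, most likely again reported as a limit. The step that the limit leaves unreadable from compound 3 to compound 4 expected from this estimate is none beyond the scatter.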

Compound 4, half-maximal inhibitory concentration: > 50000 nM
Compound 4 was reported as a limit (the forecaster's own chance of this, stated with the estimate: 65%); the middle value lies beyond the limit too.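

In this assay compound 4 gives > 50000 nM, a limit and not a number. The steps to compound 4 from compound 3 and from compound 1 cannot be read: the limit of > 50000 nM in this assay, at which 4 of the 4 values shown sit. The compounds shown leave open whether fluoro, acetyl or 4-methoxybenzyl on the shared core differ at all in this assay.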